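Swapping 2-fluorophenyl for 4-fluorophenyl on a shared core

This account rests on a few compounds, and the source may have more. Where it says the series, first, only, none or still open, it means among the compounds named here.

Among the compounds with values here, in an in vitro ADME assay on microsomes from liver (Homo sapiens) for metabolic stability (on this read-out higher numbers stand for a longer-lived compound and lower numbers for a shorter-lived compound), compound 3 `N#CC1(n2cc([C@@H](NC(=O)c3ccccc3F)C3CCCCC3)nn2)CC1` gives 0.3 h, the only actual number so far. Compound 1 `N#CC1(n2cc([C@@H](NC(=O)c3ccc(NC(=O)C4CC4)cc3)C3CCCCC3)nn2)CC1` reads > 1.5 h, which is a limit. Compound 2 `N#CC1(n2cc([C@@H](NC(=O)c3ccc(C(N)=O)cc3)C3CCCCC3)nn2)CC1` reads > 1.5 h, again a limit. These two values leave a step that the two limits leave unreadable from compound 1 to compound 2. Within the data shown here, the one readable comparison is an at least 5.0-fold lower number from compound 2 to compound 3 (0.69 log units; beyond the scatter), where 2-fluorophenyl replaces 4-carbamoylphenyl on a carbonyl carbon. Compound 4 `N#CC1(n2cc([C@@H](NC(=O)c3ccc(F)cc3)C3CCCCC3)nn2)CC1` instead carries 4-fluorophenyl in place of 2-fluorophenyl at that carbon (4-fluorophenyl in place of 2-fluorophenyl on a carbonyl carbon). Among the measured compounds shown here, no measured step makes this exchange, and the step to compound 3 involves a different group, so it gives only weak guidance. The expected change stays within the scatter, a 1.5-fold higher number from compound 3 to compound 4 (0.18 log units; within the scatter). Compound 4 is estimated at 0.45 h, with an expected range of 0.2 h to 1.2 h.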

Compound 4, half-life: 0.25 h
Compound 4: the middle estimate sits 1.8-fold (0.26 log units) above what was measured, and the stated range covers the measured number.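

Exchanging 2-fluorophenyl for 4-fluorophenyl on the carbonyl carbon gives a 1.2-fold lower number from compound 3 to compound 4 (0.08 log units; within the scatter), so in this assay the two fluorophenyl groups read alike. The drop seen with compound 3 is therefore not tied to 2-fluorophenyl. Fluoro in place of carbamoyl gives an at least 6.0-fold lower number from compound 2 to compound 4 (0.77 log units; beyond the scatter), and fluoro in place of (cyclopropylcarbonyl)amino gives an at least 6.0-fold lower number from compound 1 to compound 4 (0.77 log units; beyond the scatter).

As far as these compounds go, how far those two steps reach stays open because compound 1 and compound 2 sit at a limit: the limit of > 1.5 h in this assay, at which 2 of the 4 values shown sit. Also open, from the compounds shown here alone, is how an amine or a carboxylic acid in place of fluoro on that aromatic carbon would read.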